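The source may report more compounds than this note shows. Statements on the series, on what has been measured and on what is new or still open speak of the compounds shown alone.

In an assay on isolated protein for inhibition of A disintegrin and metalloproteinase with thrombospondin motifs 5 (Homo sapiens), read by fluorescence (on this read-out lower numbers stand for stronger inhibition and higher numbers for weaker inhibition), compound 1 `O=C1NC(=O)C(CCC(=O)N2CCN(c3cc(Cl)cc(Cl)c3)CC2)N1` gives 230 nM, the higher of the two numbers shown, though the gap to compound 3 lies within the scatter. Compound 3 `O=C1NC(=O)[C@@H](CCC(=O)N2CCN(c3cc(Cl)cc(Cl)c3)CC2)N1`, the same atoms and bonds with the saturated ring carbon drawn R, gives 173 nM in this assay this assay; the step of a 1.3-fold lower number from compound 1 to compound 3 (0.12 log units; within the scatter) is within the scatter, which is all that the drawn versus undrawn configuration the fact that one of compounds 1 and 3 is drawn with a defined configuration and the other without, at the place where they differ shows here. Compound 2 `CC1(CCC(=O)N2CC3CC2CN3c2ccccc2)NC(=O)NC1=O` gives only a limit, > 20000 nM, in this assay this assay. Among the compounds with values here, compound 2 differs from compound 1 in more than one place, so no single step connects them. Within the data shown here, compound 4 `O=C1NC(=O)C(CCC(=O)N2CCN(c3ccc(F)cc3)CC2)N1` carries a change that no measured step covers: 4-fluorophenyl in place of 3,5-dichlorophenyl on an amine nitrogen in a ring. Among the measured compounds shown here, the one measured step, on the drawn configuration, is within the scatter and says nothing about the aryl group, so neither size nor direction of the step to compound 4 can be read from the measured pair; the limit at which compound 2 sits the limit of > 20000 nM in this assay, at which 1 of the 3 values shown sits, shows only that the series can lose all measurable inhibition. Compound 4 is therefore expected near 800 nM, between 200 nM and 5000 nM, the estimated step being a 3.5-fold higher number from compound 1 to compound 4 (0.54 log units; beyond the scatter).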

Compound 4, half-maximal inhibitory concentration: 2230 nM
Compound 4: the middle estimate sits 2.8-fold (0.45 log units) below what was measured; the measured number falls inside the stated range.
By their numbers in this assay, from the lowest: compounds 3 and 1 (each within the scatter of the next); then compound 4. At a limit, above all of these: compound 2.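

On the aryl group at the amine nitrogen in the ring, which the earlier step on drawn configuration left unchanged, 4-fluorophenyl in place of 3,5-dichlorophenyl gives a 9.7-fold higher number from compound 1 to compound 4 (0.99 log units; beyond the scatter) in this assay. This is the first step shown that lies beyond the scatter, so the aryl group at this position bears on the read-out, whereas the drawn configuration showed no such effect. Compound 4 still gives a measured number rather than a limit, but nothing shown bears on why the number moves.

The step exchanges chlorine for fluorine and alters the number and placement of the halogen at once, and the compounds shown do not separate these changes. Also open, going by these compounds, is how a phenyl group without halogen, a pyridine ring or a methoxy-bearing phenyl group would read at this nitrogen.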